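This account rests on a few compounds, and the source may have more. Where it says the series, first, only, none or still open, it means among the compounds named here.

Two compounds of this series have numbers in an assay on isolated protein for binding affinity to Type-2 angiotensin II receptor (Homo sapiens); on this read-out higher numbers stand for weaker inhibition and lower numbers for stronger inhibition. Compound 1 `CCCc1nc(CC)c(C(=O)OCCC[S+]([O-])c2ccccc2)n1Cc1ccc(-c2ccccc2S(=O)(=O)NC(=O)OCCC(C)C)cc1F` gives 1 nM. Compound 2 `CCCc1nc(CC)c(C(=O)OCc2ccccc2Sc2ccccc2)n1Cc1ccc(-c2ccccc2S(=O)(=O)NC(=O)OCCC(C)C)cc1F` gives 2 nM, and the number of compound 1 lies within the scatter of it, so the two cannot be separated. Compound 3 `CCCc1nc(CC)c(C(=O)OCc2ccccc2S(=O)(=O)c2ccccc2)n1Cc1ccc(-c2ccccc2S(=O)(=O)NC(=O)OCCC(C)C)cc1F` differs from compound 2 by phenylsulfonyl in place of phenylsulfanyl on an aromatic carbon. With no measured step of this kind in the series, the expected change from compound 2 to compound 3 is a 1.5-fold higher number from compound 2 to compound 3 (0.18 log units; within the scatter), that is none beyond the scatter, leaning slightly toward a higher number. Compound 3 is expected at 3 nM, with a range of 1 nM to 10 nM.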

Compound 3, half-maximal inhibitory concentration: 5 nM
For compound 3 the middle estimate is 1.7-fold (0.22 log units) below the measured one; the range from low to high includes it.
By their numbers in this assay, from the lowest: compounds 1 and 2 (each within the scatter of the next); then compound 3.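

At this place, on an aromatic carbon ortho to a large group, phenylsulfonyl in place of phenylsulfanyl gives a 2.5-fold higher number from compound 2 to compound 3 (0.40 log units; beyond the scatter) in this assay. Within the data shown here, this is the only step that can be read, and it shows that this change registers on the read-out, though modestly. No measurement at hand gives a reason for the step.

From the compounds shown here alone, whether a phenylsulfinyl group, an amine or a carboxylic acid at this place would sit nearer compound 2 or compound 3 stays open. Compound 1 differs from both in more than one place and says nothing about this change.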